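Removing the Trifluoromethyl Group from Compound 1

The source may hold more compounds than are shown below. What is called first, only, known or untested is meant among the compounds shown, and "the series" means these compounds.

Compound 1 `O=C(O)c1ccccc1[S+]([O-])c1cccc(C(F)(F)F)c1` was tested in a functional assay on the whole organism (strain Holtzmann) for inhibition, with Rattus norvegicus as the target, at a dose of 50 mg/kg by the oral route (on this read-out lower numbers stand for less inhibition and higher numbers for more inhibition at the one dose given (going by the name of the read-out)), where it gives 2%, the lowest of the two numbers measured. Compound 2 `O=C(O)c1ccccc1S(=O)(=O)c1cccc(C(F)(F)F)c1` gives 23% in this assay, a value that lies beyond the usual scatter above compound 1. Compound 3 `O=C(O)c1ccccc1[S+]([O-])c1ccccc1` differs from compound 1 in one place: hydrogen in place of trifluoromethyl on an aromatic carbon. For the measured compounds named here, no measured pair shows this change, so its effect in this assay is unknown. Because compound 1 already gives 2%, little room remains downward. The expected step is a number 3 percentage points higher from compound 1 to compound 3 (within the scatter), no larger than the scatter. Compound 3 is therefore expected to give about 5%, likely between 0% and 20%.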

Compound 3, a percentage reported as inhibition, in the whole organism at one dose (the size of the read-out at that dose, not a potency): 0%
The estimate for compound 3 lay 5 percentage points above the measured number, and the stated range covers the measured number.
By their numbers in this assay, from the lowest: compounds 3 and 1 (each within the scatter of the next); then compound 2.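

In this assay, hydrogen in place of trifluoromethyl gives a number 2 percentage points lower from compound 1 to compound 3 (within the scatter), so this change on the aromatic carbon has no readable effect on the core of compound 1. Both compounds sit at the bottom of the read-out, however, where any further loss could hardly show. Nothing measured here offers an explanation for this result.

Still open, as far as these compounds go, is whether an amine or a methoxy group at this position would raise the number in this assay. The same change also remains to be seen on compound 2, which gives 23% and so has more room to fall.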